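A few compounds are considered here, and "the series" means these few. Any claim that something is new, unique, unknown or untested is made for them only; others in the source may bear on it.

In a functional assay on MCF7 cells (Homo sapiens) for cytotoxicity, read by WST assay, with a stated time of 72 h (on this read-out lower numbers stand for stronger inhibition and higher numbers for weaker inhibition), compound 1 `O=C1Nc2c(ccc(F)c2F)C1(c1ccccc1)c1ccc(O)cc1` gives 7.1 nM while compound 2 `O=C1Nc2c(ccc(F)c2F)C1(c1ccc(O)cc1)c1ccc(F)c(F)c1` gives 7.8 nM and compound 3 `O=C1Nc2c(ccc(F)c2F)C1(c1ccc(O)cc1)C1CCCC1` gives 12 nM on the same read-out. Compound 3 thus stands level with the other two, as its gaps to both lie within the scatter.

Compound 4 `O=C1Nc2c(ccc(F)c2F)C1(c1ccc(O)cc1)C1CCCCCC1` differs from compound 3 by one swap on a saturated ring carbon (cycloheptyl in place of cyclopentyl on a saturated ring carbon), where a seven-membered non-aromatic ring of carbon only takes the place of a five-membered one. Two measured steps change the group on that same carbon (a 1.7-fold higher number from compound 1 to compound 3 (0.23 log units; within the scatter) and a 1.5-fold higher number from compound 2 to compound 3 (0.19 log units; within the scatter)), and both stay within the scatter. The step between the two aromatic groups (a 1.1-fold higher number from compound 1 to compound 2 (0.04 log units; within the scatter)) does too. None of these steps compares two saturated rings of different size, so the evidence is indirect. In this assay no step beyond the scatter is therefore expected, in either direction. The expected step is small (a 1.2-fold higher number from compound 3 to compound 4 (0.07 log units; within the scatter)) and lies within the scatter. For compound 4 the estimated value is 14 nM (expected range 5 nM to 40 nM).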

Compound 4, half-maximal inhibitory concentration: 1.2 nM
Compound 4: the middle estimate sits 12-fold (1.07 log units) above what was measured, and the stated range ends above it.
By their numbers in this assay, from the lowest: compound 4; then compounds 1, 2 and 3 (each within the scatter of the next).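

In this assay, swapping phenyl, 3,4-difluorophenyl and cyclopentyl on this saturated ring carbon had moved the number only within the scatter, but enlarging the saturated ring to cycloheptyl gives a 10-fold lower number from compound 3 to compound 4 (1.00 log units; beyond the scatter), so this position does respond to the group placed there. The cycloheptyl group also separates from both aromatic groups, with a 6.5-fold lower number from compound 2 to compound 4 (0.81 log units; beyond the scatter) and a 5.9-fold lower number from compound 1 to compound 4 (0.77 log units; beyond the scatter), which gives it the lowest number of the four groups shown. No measurement here explains why the larger ring gives the lower number.

On these data alone, whether cyclohexyl would sit closer to cyclopentyl or to cycloheptyl, and whether cyclooctyl would go lower still, remains open. Also open, as far as these compounds go, is whether a ring is needed at all, as an open heptyl chain would test, and whether a piperidine ring, with a nitrogen in place of one ring carbon, would keep the low number.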